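The compounds below may be only part of what the source reports. "The series", "measured", "known", "first", "only" and "open" are said of these compounds alone.

Measured so far:
- compound 1, `CCN1CCN(CC(=O)Nc2nc3ccccc3[nH]2)CC1`, 65.8%
- compound 2, `O=C(CN1CCN(c2ccccc2)CC1)Nc1nc2ccccc2[nH]1`, 62.1%
- compound 3, `O=C(CN1CCN(c2ccccn2)CC1)Nc1nc2ccccc2[nH]1`, 76.2%

All three share one core and differ only in the group on the amine nitrogen in the ring. In a functional assay, read by spectrophotometry, with a stated time of 30 min, tested at 200 ug/mL (a lower number here means a weaker effect, a higher number a stronger effect of the compound at the concentration tested), compound 2 gives the lowest of the three numbers, yet a number 3.7 percentage points lower from compound 1 to compound 2 (within the scatter), so these two cannot be told apart. Compound 3 stands clearly higher: a number 14.1 percentage points higher from compound 2 to compound 3 (beyond the scatter), and a number 10.4 percentage points higher from compound 1 to compound 3 (beyond the scatter).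

Compound 4, `O=C(CN1CCN(c2ccc([N+](=O)[O-])cc2)CC1)Nc1nc2ccccc2[nH]1`, is not yet measured. It differs from compound 2 by nitro in place of hydrogen on an aromatic carbon. Among the compounds with values here, no measured step touches the phenyl group itself; the only steps known replace the whole group on the amine nitrogen. Of these, a number 14.1 percentage points higher from compound 2 to compound 3 (beyond the scatter) shows that a change in that part of the molecule can shift the number modestly, while a number 3.7 percentage points lower from compound 1 to compound 2 (within the scatter) shows that it can also leave it unchanged. Nothing here tells in which direction a nitro group would move the number, so the expectation for compound 4 is a step of about a number 2.9 percentage points higher from compound 2 to compound 4 (within the scatter), with a range that allows a modest change either way.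

The estimate for compound 4 in this assay is therefore 65%, expected to lie between 50% and 80%.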

Compound 4, a percentage reported as activity, at one concentration (the size of the read-out at that concentration, not a potency): 76.7%
Beside the measured number, compound 4's estimate is 11.7 percentage points below it; measured number inside the range.
By their numbers in this assay, from the lowest: compounds 2 and 1 (each within the scatter of the next); then compounds 3 and 4 (each within the scatter of the next).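

In this assay the phenyl group itself turns out to be a place where a small addition counts: nitro on an aromatic carbon, para to a large group, gives a number 14.6 percentage points higher from compound 2 to compound 4 (beyond the scatter) and so moves the number as far as replacing the whole phenyl group with pyridin-2-yl did. The two changes reach the same level, since 4-nitrophenyl in place of pyridin-2-yl gives a number 0.5 percentage points higher from compound 3 to compound 4 (within the scatter) and the two compounds cannot be told apart, while 4-nitrophenyl in place of ethyl gives a number 10.9 percentage points higher from compound 1 to compound 4 (beyond the scatter) and so joins pyridin-2-yl in standing clear of ethyl. Nothing shown here explains why adding nitro raises the number or why these two different groups end up level.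

On these data alone, it remains open whether this rise belongs to nitro in particular or would also appear with another group, such as an amine or a carboxylic acid, on that same aromatic carbon. As far as these compounds go, it is also open whether a nitro group added to the pyridin-2-yl group of compound 3 would raise the number further or leave it where it stands.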